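The source may hold more compounds than are shown below. What is called first, only, known or untested is meant among the compounds shown, and "the series" means these compounds.

Three compounds have numbers in an assay on CHO cells for displacement of a labelled ligand from adenosine receptor A3 (Homo sapiens), read by scintillation counting, with a stated time of 60 min; a lower number here means a stronger inhibitor, a higher number a weaker inhibitor:

compound 1, `Nc1nc(-c2ccccc2)nc2cn(Cc3ccccc3)nc12`, gives 54 nM
compound 2, `Nc1nc(-c2cccs2)nc2cn(-c3ccccc3)nc12`, gives 9.7 nM
compound 3, `Cc1nc2cn(-c3ccccc3F)nc2c(=O)[nH]1`, gives 225 nM

Among these, compound 2 stands lowest, and so is the strongest inhibitor in this assay; compound 1 is nearest to it, while compound 3 lies furthest away, and both gaps go beyond the scatter of the assay. No pair of these compounds differs in only one place, so no single measured step can be read off.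

Compound 4, `COc1ccc(-c2nc(N)c3nn(-c4ccccc4)cc3n2)cc1`, is not yet measured. It is compound 2 with one change: 4-methoxyphenyl in place of thiophen-2-yl on an aromatic carbon. The measured compounds give no direct guide for swapping one ring for the other at this position, since compound 1 and compound 2 differ in more than one place. Given that, a modest loss, not far beyond the scatter, seems the most likely outcome; the step from compound 2 to compound 4 in this assay is expected to be a 2.1-fold higher number from compound 2 to compound 4 (0.31 log units; beyond the scatter). For compound 4 the estimate is 20 nM, with a range from 5 nM to 80 nM.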

Compound 4, inhibition constant: 33 nM
Estimate against measurement, compound 4: 1.7-fold (0.22 log units) below, and the stated range covers the measured number.
By their numbers in this assay, from the lowest: compound 2; then compounds 4 and 1 (each within the scatter of the next); then compound 3.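

In this assay, 4-methoxyphenyl in place of thiophen-2-yl, on the aromatic carbon between two ring nitrogen atoms, gives a 3.4-fold higher number from compound 2 to compound 4 (0.53 log units; beyond the scatter). Among these compounds, this is the first direct reading of a ring swap at this position, and it shows a modest loss that lies beyond the scatter: the five-membered sulfur ring gives the lower number of the two, yet the six-membered ring with its methoxy group still leaves compound 4 at 33 nM. Nothing shown here bears on why the number rises.

Whether the ring or its methoxy group accounts for the step remains open, and a plain phenyl at this carbon, with the rest of compound 2 unchanged, would help separate the two. How a 4-hydroxyphenyl or a 4-aminophenyl would fare here is also unknown.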